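Propoxy to allyloxy: what compound 4 may show

The source may hold more compounds than are shown below. What is called first, only, known or untested is meant among the compounds shown, and "the series" means these compounds.

Compound 1 `Cc1cc(=O)c(O)c(C(c2ccc(OCc3ccc([N+](=O)[O-])cc3)cc2)c2oc(C)cc(=O)c2O)o1`: 3060 nM
Compound 2 `Cc1cc(=O)c(O)c(C(c2ccc(CCc3ccccc3)cc2)c2oc(C)cc(=O)c2O)o1`: > 50000 nM, a limit of the assay
Compound 3 `CCCOc1ccc(C(c2oc(C)cc(=O)c2O)c2oc(C)cc(=O)c2O)cc1`: 26600 nM

In a functional assay on HT-1080 cells (Homo sapiens) for antiproliferative activity, read by MTT assay (on this read-out lower numbers stand for stronger inhibition and higher numbers for weaker inhibition), compound 3 gives 26600 nM, the higher of the two actual numbers. Compound 2 gives only a limit.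

Compound 4 `C=CCOc1ccc(C(c2oc(C)cc(=O)c2O)c2oc(C)cc(=O)c2O)cc1` differs from compound 3 in one place: vinyl in place of ethyl on a saturated chain carbon bound to an oxygen on an aromatic ring. It carries vinyl in place of ethyl on a saturated chain carbon bound to an oxygen on an aromatic ring.

The closest evidence is an 8.7-fold higher number from compound 1 to compound 3 (0.94 log units; beyond the scatter), where ethyl replaced 4-nitrophenyl at that place. The other steps, an at least 16-fold higher number from compound 1 to compound 2 (1.21 log units; beyond the scatter) and an at least 1.8-fold lower number from compound 2 to compound 3 (0.27 log units; that floor lies within the scatter), involve larger exchanges at the aromatic carbon. Since ethyl to vinyl is a far smaller exchange than any of these, no step beyond the scatter is expected. The expected result is a 1.2-fold lower number from compound 3 to compound 4 (0.06 log units; within the scatter). Compound 4 is estimated at 23000 nM, with an expected range of 10000 nM to 48000 nM.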

Compound 4, half-maximal inhibitory concentration: 28300 nM
Compound 4: middle estimate off by 1.2-fold (0.09 log units), on the low side; the range from low to high includes it.
By their numbers in this assay, from the lowest: compound 1; then compounds 3 and 4 (each within the scatter of the next). At a limit, above all of these: compound 2.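

In this assay, among the compounds shown here, the exchange of ethyl for vinyl gives a 1.1-fold higher number from compound 3 to compound 4 (0.03 log units; within the scatter), so this place shows no readable response to a double bond, which no earlier step had tested. With vinyl, as with ethyl in compound 3, the loss of 4-nitrophenyl goes with a weaker result: a 9.2-fold higher number from compound 1 to compound 4 (0.97 log units; beyond the scatter). Compound 2 is only a limit, so its comparison gives an at least 1.7-fold lower number from compound 2 to compound 4 (0.24 log units; that floor lies within the scatter), a floor and no more: the limit of > 50000 nM in this assay, at which 1 of the 4 values shown sits.

Going by these compounds, whether an amine or a longer chain at this place would move the number remains open. So does which part of the 4-nitrophenyl group goes with the stronger result of compound 1.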